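Lengthening the chain from compound 1 to compound 4

The source may report more compounds than this note shows. Statements on the series, on what has been measured and on what is new or still open speak of the compounds shown alone.

Measured in a functional assay on MCF7 cells (Homo sapiens) for antiproliferative activity, read by MTT assay, with a stated time of 72 h; a lower number here means a stronger inhibitor, a higher number a weaker inhibitor:
Compound 1 `CCCCCCCCNC[C@@H]1OC[C@H](N)[C@@H]1O`: 96600 nM
Compound 2 `CCCCCCCNC[C@@H]1OC[C@H](N)[C@@H]1O`: > 128000 nM, a limit and not a number
Compound 3 `CCCCCCCCCCCNC[C@@H]1OC[C@H](N)[C@@H]1O`: 6770 nM

Only compound 1 and compound 3 have true numbers, and compound 1 holds the higher of the two, so it is the weaker inhibitor of that pair. Compound 4 `CCCCCCCCCCCCNC[C@@H]1OC[C@H](N)[C@@H]1O` has not yet been measured. Its difference from compound 1 is butyl in place of hydrogen on a saturated chain carbon, eight bonds along the chain from an amine nitrogen.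

Among the compounds with values here, the closest precedent puts propyl in place of hydrogen at that same place, and it gives a large step: a 14-fold lower number from compound 1 to compound 3 (1.15 log units; beyond the scatter). A similar large step appears with butyl on the shorter chain: an at least 18-fold lower number from compound 2 to compound 3 (1.27 log units; beyond the scatter). The remaining step, an at least 1.3-fold higher number from compound 1 to compound 2 (0.12 log units; that floor lies within the scatter), has a floor within the scatter, so it adds little.

In these three compounds, the longest chain gives the lowest number, and none goes against that. Nothing measured shows whether the trend continues past compound 3. A large drop in this assay is still expected, somewhat beyond the propyl step, and the estimated step is a 28-fold lower number from compound 1 to compound 4 (1.44 log units; beyond the scatter). Compound 4 is expected at about 3500 nM, with an estimated range of 1200 nM to 10000 nM.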

Compound 4, half-maximal inhibitory concentration: 1800 nM
The estimate for compound 4 lay 1.9-fold (0.29 log units) above the measured number; the measured number falls inside the stated range.
By their numbers in this assay, from the lowest: compound 4; then compound 3; then compound 1. At a limit, above all of these: compound 2.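

In this assay, butyl in place of hydrogen on a saturated chain carbon, eight bonds along the chain from an amine nitrogen, gives a 54-fold lower number from compound 1 to compound 4 (1.73 log units; beyond the scatter), and the fall does not stop at compound 3, since one more methyl at the chain's far end still gives a 3.8-fold lower number from compound 3 to compound 4 (0.58 log units; beyond the scatter). Compound 2 carries a limit, > 128000 nM, and not a number. Within the data shown here, the step that starts from that limit, an at least 71-fold lower number from compound 2 to compound 4 (1.85 log units; beyond the scatter), is therefore only a floor, though it points the same way, with the longest chain giving the lowest number and no compound here going against that.

As far as these compounds go, whether a longer chain than that of compound 4 lowers the number further, or the fall levels off, stays open. So does whether an amine or a carboxylic acid at the chain end would keep this activity.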